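Methoxy in place of methyl on a weak kinase inhibitor

The source may hold more compounds than are shown below. What is called first, only, known or untested is meant among the compounds shown, and "the series" means these compounds.

Three compounds share a core in which a cyclic imide is joined through a single carbon to an aniline nitrogen. Compound 1 `O=C1c2ccccc2C(=O)N1CNc1ccc(Cl)cc1` carries a chlorine on the aniline ring; in an assay on isolated protein for inhibition of ribosomal protein S6 kinase alpha-2 (Homo sapiens), read by fluorescence, with a stated time of 20 min (on this read-out higher numbers stand for weaker inhibition and lower numbers for stronger inhibition), compound 1 gives "not determined" (no result reported), meaning no result was reported. Going by the values given here, compound 2 `Cc1ccc(NCN2C(=O)c3ccccc3C2=O)cc1` carries a methyl on that ring instead, and in this assay compound 2 gives 4300 nM, a weak inhibition and the only number available, so compound 2 stands as the sole reference point here.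

Compound 3 `COc1ccc(NCN2C(=O)c3ccccc3C2=O)cc1` differs from compound 2 in one place: methoxy in place of methyl on an aromatic carbon. No comparable exchange between measured compounds is available, so nothing shows how this series responds to such a change. The step from compound 2 to compound 3 is therefore expected to be small, in either direction, and most likely within the usual scatter of repeated measurements, as the estimated 1.1-fold lower number from compound 2 to compound 3 (0.03 log units; within the scatter) expresses. On this basis compound 3 is expected to give about 4000 nM in this assay, with a plausible range from 1500 nM to 12000 nM.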

Compound 3, half-maximal inhibitory concentration: 470 nM
For compound 3 the middle estimate is 8.5-fold (0.93 log units) above the measured one; measured number below the stated range.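

In this assay, putting methoxy in place of methyl on the aromatic carbon para to a large group gives a 9.1-fold lower number from compound 2 to compound 3 (0.96 log units; beyond the scatter), a step beyond the usual scatter of repeated measurements. With compound 2 alone, there was only a single weak reference point; this pair shows that the group at this position can strongly affect inhibition, and that this one exchange moves the series toward stronger inhibition. The structures show that the entering methoxy brings an oxygen and a counted hydrogen-bond acceptor that methyl lacks, but no measurement here shows what lies behind the stronger inhibition.

Compound 1 has no number, so its chlorine cannot be placed against methyl or methoxy, and any step involving it cannot be read. The compounds shown leave open whether a hydroxyl, an ethoxy or an amine at the same position would match or exceed methoxy, and whether methoxy would have a comparable effect elsewhere on this ring.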